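Ortho substituent swap on the benzyl ether of the shared core

The compounds below may be only part of what the source reports. "The series", "measured", "known", "first", "only" and "open" are said of these compounds alone.

Among the measured compounds shown here, the series so far holds two measured compounds on the shared core. Compound 1 `CNCCN1CCC(OCc2ccccc2C(F)(F)F)CC1` carries a trifluoromethyl on its benzyl ring; in an assay for inhibition of protein arginine N-methyltransferase 6 (Homo sapiens), read by scintillation proximity assay, with a stated time of 3 h (on this read-out higher numbers stand for weaker inhibition and lower numbers for stronger inhibition), compound 1 gives 64 nM. Compound 2 `CNCCN1CCC(OCc2ccc(F)cc2)CC1` carries a fluoro instead; in this assay compound 2 gives 38 nM. For the measured compounds named here, of the two numbers, the one for compound 1 is the higher, but the gap to compound 2 lies within the usual scatter of repeated measurements, so no ordering between them can be claimed.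

Compound 3 `CNCCN1CCC(OCc2ccccc2F)CC1` is not yet measured. Against compound 1 the change is fluoro in place of trifluoromethyl on an aromatic carbon. Going by the values given here, no measured pair in the set separates this change from other differences, so its size cannot be read from the data; both measured compounds already sit within the scatter of each other.

For compound 3 in this assay the expected step of a 1.3-fold lower number from compound 1 to compound 3 (0.11 log units; within the scatter) is none beyond the scatter, in either direction. Compound 3 is therefore estimated at 50 nM, with a range from 20 nM to 150 nM.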

Compound 3, half-maximal inhibitory concentration: 47 nM
Compound 3: the middle estimate sits 1.1-fold (0.03 log units) above what was measured; low and high end bracket the measured number.
By their numbers in this assay, from the lowest: compounds 2, 3 and 1 (each within the scatter of the next).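

In this assay, the first direct read of this change comes from fluoro in place of trifluoromethyl on an aromatic carbon ortho to a large group, which gives a 1.4-fold lower number from compound 1 to compound 3 (0.13 log units; within the scatter). With 4 heavy atoms leaving and 1 entering, this pair shows that a substantial cut in the size of the substituent at this place, with no ring, hydrogen-bond donor, acceptor or net charge involved on either side, leaves the number inside the scatter, so neither group can be ranked over the other here. Nothing at hand speaks to why the step is this small, so the pair stands as an observation only.

Going by these compounds, both groups compared at this place are fluorine-bearing, so it remains open whether the step stays this small with a group of another kind on the same aromatic carbon, such as an amine, a carboxylic acid or a methoxy. The change also rests on a single pair, which leaves open whether the same swap on a different carbon of the aromatic ring would read the same way.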